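Methoxy for nitro at the limit of the assay

A few compounds are considered here, and "the series" means these few. Any claim that something is new, unique, unknown or untested is made for them only; others in the source may bear on it.

compound 1 (`O=C(NNC(=S)Nc1ccc([N+](=O)[O-])cc1)c1ccncc1`) gives > 300000 nM as a limit
compound 2 (`CCc1cccc(NC(=S)NNC(=O)c2ccncc2)c1`) gives > 300000 nM as a limit
compound 3 (`Cc1cccc(C)c1NC(=S)NNC(=O)c1ccncc1`) gives > 300000 nM as a limit

In an ADME assay on MCF-10A cells (Homo sapiens) for cytotoxicity, read by WST assay, with a stated time of 48 h (a lower number here means a stronger inhibitor, a higher number a weaker inhibitor), compound 1 gives > 300000 nM as a limit of the assay and not as a number. Among the measured compounds shown here, compound 1, compound 2 and compound 3 all stand at the limit of > 300000 nM in this assay, at which 3 of the 3 values shown sit, and so cannot be ranked, and no measured step links them. Compound 4 (`COc1ccc(NC(=S)NNC(=O)c2ccncc2)cc1`) carries methoxy in place of nitro on an aromatic carbon, para to a large group (methoxy in place of nitro on an aromatic carbon). For this change in this assay the expectation is no step beyond the usual scatter and no clear direction. That expectation rests on compound 1, whose > 300000 nM is a limit. The expected step is a number no higher from compound 1 to compound 4 (the limit leaves the size open) and it may well show up only as a limit again. Compound 4 is expected at 300000 nM with 100000 nM to 600000 nM as its estimated range before the measurement is known.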

Compound 4, half-maximal inhibitory concentration: 47500 nM
Beside the measured number, compound 4's estimate is 6.3-fold (0.80 log units) above it; measured number below the stated range.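

In this assay, methoxy in place of nitro on an aromatic carbon, para to a large group, gives an at least 6.3-fold lower number from compound 1 to compound 4 (0.80 log units; beyond the scatter), which shows that a change at this position can bring a measurable value in this assay. Going by these compounds, compound 1 gives > 300000 nM, which is a limit of the assay, so the full size of the step remains open. Compound 4 is the only compound shown with a number rather than a limit, and the earlier compounds could not be ranked: the limit of > 300000 nM in this assay, at which 3 of the 4 values shown sit.

The compounds shown leave open whether the step depends on the arrival of methoxy or on the departure of nitro. They also leave open whether an amine, a hydroxyl or a longer chain on the same aromatic carbon would give a measured value or stay at the limit.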